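A hydrogen atom in compound 4

A few compounds are considered here, and "the series" means these few. Any claim that something is new, unique, unknown or untested is made for them only; others in the source may bear on it.

In an ADME assay on MT4 cells (Homo sapiens) for cytotoxicity (on this read-out lower numbers stand for higher toxicity in this test and higher numbers for lower toxicity in this test), compound 1 `COC(=O)N[C@H](C(=O)NN(CCC[C@@](O)(Cc1ccccc1)C(=O)N[C@H]1c2ccccc2C[C@H]1O)Cc1ccc(Br)cc1)C(C)(C)C` gives > 10000 nM, which is a limit and not a number. Compound 2 `COC(=O)N[C@H](C(=O)NN(CCC[C@@](O)(Cc1ccccc1)C(=O)N[C@H]1c2ccccc2C[C@H]1O)Cc1ccc(-c2ccncc2)cc1)C(C)(C)C` gives > 10000 nM, again a limit. On these data alone, compound 3 `COC(=O)N[C@H](C(=O)NN(CCC[C@](Cc1ccccc1)(O[Si](C)(C)C(C)(C)C)C(=O)N[C@H]1c2ccccc2C[C@H]1O[Si](C)(C)C(C)(C)C)Cc1ccc(Br)cc1)C(C)(C)C` gives > 10000 nM, a limit as well, so its true position on this assay remains unknown. For the measured compounds named here, the series so far is summed up by the limit of > 10000 nM in this assay, at which 3 of the 3 values shown sit.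

Compound 4 `COC(=O)N[C@H](C(=O)NN(CCC[C@](Cc1ccccc1)(O[Si](C)(C)C(C)(C)C)C(=O)N[C@H]1c2ccccc2C[C@H]1O)Cc1ccc(Br)cc1)C(C)(C)C` follows from compound 3 through one change: a hydrogen atom in place of a group of 7 heavy atoms (6 carbon, 1 silicon; no ring), on an oxygen on a saturated carbon. A hydrogen atom enters on an oxygen on a saturated carbon, where the group without a ring leaves.

Going by the values given here, the only measured step is a step that the two limits leave unreadable from compound 1 to compound 2. It involves a different change and gives no size to carry over to this one. Among the compounds with values here, no measured step therefore shows what this exchange does in this assay. With no readable step to draw on, the expectation rests on compound 3 at > 10000 nM, and no step beyond the scatter is expected in either direction. The expected step is a step that the limit leaves unreadable from compound 3 to compound 4. A further limit is the most likely report for compound 4. For compound 4 the estimated value is 15000 nM, with an expected range from 7000 nM to 40000 nM.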

Compound 4, half-maximal cytotoxic concentration: 5800 nM
The estimate for compound 4 lay 2.6-fold (0.41 log units) above the measured number; the whole stated range lies above it.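

For the compounds shown here, compound 4 is the only compound here that gives a number rather than a limit in this assay: the limit of > 10000 nM in this assay, at which 3 of the 4 values shown sit. With a hydrogen atom in place of the group of 7 heavy atoms on the oxygen on a saturated carbon, the series shows an at least 1.7-fold lower number from compound 3 to compound 4 (0.23 log units; that floor lies within the scatter), the first sign that this position can bear on the read-out, although the floor of the step does not pass the scatter. Seen from the other side, the same group set in place of a hydrogen atom on an oxygen gives an at least 1.7-fold lower number from compound 1 to compound 4 (0.23 log units; that floor lies within the scatter), so compound 4, with one such group and one free hydroxyl, is set against both compound 1, which has none, and compound 3, which has two.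

On these data alone, both of these steps start from a limit, so their true sizes stay open, and the step between compound 1 and compound 2 cannot be read at all. Also open, as far as these compounds go, is whether a smaller group on this oxygen, such as a methyl or an acetyl, would give a number or another limit, and whether the bromo in compound 4 plays any part in the result.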